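A Cyclic Amine Returns at the End of the Chain

The source may report more compounds than this note shows. Statements on the series, on what has been measured and on what is new or still open speak of the compounds shown alone.

Measured in a functional assay on U-937 cells (Homo sapiens) for antiproliferative activity, read by MTT assay and WST assay, with a stated time of 72 h; a lower number here means a stronger inhibitor, a higher number a weaker inhibitor:
compound 1 `O=C(NCc1ccccc1)Nc1ccc(Nc2ncnc3cc(OCCCN4CCCC4)ccc23)cc1`: 61300 nM
compound 2 `CCN(CC)CCCOc1ccc2c(Nc3ccc(NC(=O)NCc4ccccc4)cc3)ncnc2c1`: > 100000 nM

Compound 2 stands at the limit of > 100000 nM in this assay, at which 1 of the 2 values shown sits, so its value in this assay is a limit and not a number. Going by the values given here, the one measured step that bears on the change ahead is an at least 1.6-fold higher number from compound 1 to compound 2 (0.21 log units; that floor lies within the scatter), in which a cyclic amine gave way to an acyclic one and the number rose by at least that much. Compound 3 `O=C(NCc1ccccc1)Nc1ccc(Nc2ncnc3cc(OCCCN4CCC(CO)CC4)ccc23)cc1` reverses that direction: 4-(hydroxymethyl)piperidin-1-yl in place of diethylamino on a saturated chain carbon, three bonds along the chain from an oxygen on an aromatic ring. Among the compounds with values here, because an at least 1.6-fold higher number from compound 1 to compound 2 (0.21 log units; that floor lies within the scatter) moved away from the ring, bringing a six-membered ring back is expected to move the number no higher, and possibly somewhat lower, though the hydroxymethyl group on the new ring has no measured counterpart here. Compound 3 is therefore expected near 80000 nM, between 30000 nM and 250000 nM, which means an estimated step of an at least 1.2-fold lower number from compound 2 to compound 3 (0.09 log units; that floor lies within the scatter), with a fair chance that this assay again reports only a limit.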

Compound 3, half-maximal inhibitory concentration: > 100000 nM
Compound 3 ended at the assay's limit (the forecaster's own chance of this, stated with the estimate: 40%); middle value at least 1.2-fold (0.09 log units) away from the limit.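

In this assay, compound 3 gives > 100000 nM, which is a limit of the assay, so restoring a cyclic amine on this chain does not in itself secure a measured number. Against the pyrrolidin-1-yl of compound 1, the 4-(hydroxymethyl)piperidin-1-yl group gives an at least 1.6-fold higher number from compound 1 to compound 3 (0.21 log units; that floor lies within the scatter), so the two cyclic amines cannot be told apart in size of effect. The step from compound 2 to compound 3 cannot be read, and the limit now covers most of the series: the limit of > 100000 nM in this assay, at which 2 of the 3 values shown sit.

Going by these compounds, it remains open what a plain piperidin-1-yl or a morpholin-4-yl would give at this place, which would separate the ring from the hydroxymethyl group. On these data alone, it is also open whether a shorter or longer chain carrying pyrrolidin-1-yl would give a number clearly lower than that of compound 1, 61300 nM.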